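The compounds below may be only part of what the source reports. "The series", "measured", "known", "first", "only" and "open" are said of these compounds alone.

Compound 1 `Cn1cc(C2=C(c3nn(CCCn4cccc4)c4ncccc34)C(=O)NC2=O)c2ccccc21` carries the shared core with a 3-(1H-pyrrol-1-yl)propyl chain on an aromatic nitrogen and a free amide-type nitrogen in the ring. In a functional assay on ECa-109 cells (Homo sapiens) for antiproliferative activity, read by MTT assay, with a stated time of 48 h (a lower number here means a stronger inhibitor, a higher number a weaker inhibitor), compound 1 gives > 100000 nM, which is a limit of the assay and not a number. Compound 2 `Cn1cc(C2=C(c3nn(CCCCn4ccnc4)c4ncccc34)C(=O)NC2=O)c2ccccc21` differs from compound 1 by (1H-imidazol-1-yl)methyl in place of 1H-pyrrol-1-yl on a saturated chain carbon, three bonds along the chain from an aromatic nitrogen. In this assay compound 2 gives 23500 nM. The change brought an at least 4.2-fold lower number from compound 1 to compound 2 (0.62 log units; beyond the scatter).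

Compound 3 `Cn1cc(C2=C(c3nn(CCCn4cccc4)c4ncccc34)C(=O)N(c3ccccc3)C2=O)c2ccccc21` differs from compound 1 in its core by phenyl in place of hydrogen on an amide-type nitrogen in a ring. In this assay compound 3 gives > 100000 nM, again a limit rather than a number. The comparison reads a step that the two limits leave unreadable from compound 1 to compound 3 because of the limit of > 100000 nM in this assay, at which 2 of the 3 values shown sit.

Compound 4 `Cn1cc(C2=C(c3nn(CCCCn4ccnc4)c4ncccc34)C(=O)N(c3ccccc3)C2=O)c2ccccc21` has not yet been measured. Within the data shown here, it differs from compound 3 by (1H-imidazol-1-yl)methyl in place of 1H-pyrrol-1-yl on a saturated chain carbon, three bonds along the chain from an aromatic nitrogen, the same change as the one between compound 1 and compound 2, at the same place. The expected step in this assay is an at least 2.5-fold lower number from compound 3 to compound 4 (0.39 log units; beyond the scatter), resting on the measured at least 4.2-fold lower number from compound 1 to compound 2 (0.62 log units; beyond the scatter). Compound 4 is therefore estimated at 40000 nM, with an expected range from 12000 nM to 100000 nM.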

Compound 4, half-maximal inhibitory concentration: 7540 nM
Compound 4: middle estimate off by 5.3-fold (0.72 log units), on the high side; the whole stated range lies above it.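

In this assay, the same change also lowers the number on the core of compound 3, an at least 13-fold lower number from compound 3 to compound 4 (1.12 log units; beyond the scatter), so its direction carries over from one core to the other in this pair of cores: the same change on two cores in this assay, an at least 4.2-fold lower number (0.62 log units; beyond the scatter) from compound 1 to compound 2 and an at least 13-fold lower number (1.12 log units; beyond the scatter) from compound 3 to compound 4; the limit leaves it open whether they differ. How much of the step carries over cannot be read, and neither can the phenyl step on the 3-(1H-pyrrol-1-yl)propyl chain, as both start from a limit and not a number: the limit of > 100000 nM in this assay, at which 2 of the 4 values shown sit. With the 4-(1H-imidazol-1-yl)butyl chain in place, the phenyl step can be read, a 3.1-fold lower number from compound 2 to compound 4 (0.49 log units; beyond the scatter), but this one pair shows no general effect of phenyl on the amide-type nitrogen.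

The ring and the chain length change together in this step, so the compounds shown leave open which of them goes with the lower numbers; a 4-(1H-pyrrol-1-yl)butyl chain or a 3-(1H-imidazol-1-yl)propyl chain would separate the two. Also open, as far as these compounds go, is how a benzyl or a methyl on the amide-type nitrogen would read.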